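Shifting the Pyrazole Attachment on a Weak Agonist

This account rests on a few compounds, and the source may have more. Where it says the series, first, only, none or still open, it means among the compounds named here.

Compound 1 `Cc1ccc(OCC(=O)N(Cc2cccs2)c2cnn(C)c2)cc1` was tested in an assay on HEK293 cells for agonist activity at transient receptor potential cation channel subfamily M member 8 (Homo sapiens), read by fluorescence and calcium flux, with a stated time of 15 min (a lower number here means that less compound is needed, a higher number that more compound is needed for the effect), where compound 1 gives 63000 nM. Among the two compounds with a reported number, compound 1 stands highest: compound 2 `COc1ccc2oc(C(=O)N(Cc3cccs3)c3ccn[nH]3)cc2c1`, built on a different core, gives 1.1 nM in this assay, a gap far beyond the scatter. Compound 3 `CCN(Cc1cccs1)C(=O)COc1ccc(C(=O)O)cc1` is reported in this assay as "not active" (no number reported), with no number attached.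

Compound 4 `Cc1ccc(OCC(=O)N(Cc2cccs2)c2ccnn2C)cc1` keeps every atom of compound 1 but joins them differently: 1-methyl-1H-pyrazol-5-yl in place of 1-methyl-1H-pyrazol-4-yl on an amide-type nitrogen. Within the data shown here, no measured pair isolates this change, so the direction is not anchored by data. Compound 1 sits close to the weak end of what the assay reports, and the account expects compound 4 to remain in the same region, with a step from compound 1 to compound 4 of a 1.4-fold lower number from compound 1 to compound 4 (0.15 log units; within the scatter) expected to stay within or only slightly beyond the scatter, in either direction. Compound 4 is therefore estimated at 45000 nM in this assay, within a range of 9000 nM to 200000 nM.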

Compound 4, half-maximal effective concentration: 422 nM
Compound 4: the middle estimate sits 110-fold (2.03 log units) above what was measured, and the stated range ends above it.
By their numbers in this assay, from the lowest: compound 2; then compound 4; then compound 1.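

In this assay the way the pyrazole is joined to the amide-type nitrogen proves to matter a great deal: 1-methyl-1H-pyrazol-5-yl in place of 1-methyl-1H-pyrazol-4-yl gives a 150-fold lower number from compound 1 to compound 4 (2.17 log units; beyond the scatter) with no atom added or lost. Among these compounds, this is the first pair here that differs in one place only, so the earlier compounds could not isolate this position, whereas this pair shows it to be sensitive even with the counts of hydrogen-bond donors and acceptors unchanged. No measurement shown here accounts for the size of the step.

From the compounds shown here alone, whether a 1-methyl-1H-pyrazol-3-yl group at the same place would give a lower or a higher number remains open. Going by these compounds, it is also open whether the same change would give a step of similar size on a different core, such as that of compound 2.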